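This account rests on a few compounds, and the source may have more. Where it says the series, first, only, none or still open, it means among the compounds named here.

For the measured compounds named here, in a physicochemical assay for solubility, read by HPLC, in phosphate buffer, with a stated time of 16 h, at pH 6.8 (a lower number here means a less soluble compound, a higher number a more soluble compound), compound 1 `C[C@H](NC(=O)Cn1nnc2ccccc2c1=O)c1ccc(Br)cc1` gives 900 nM, and compound 2 `Cc1ccc([C@H](C)NC(=O)Cn2nnc3ccccc3c2=O)nc1` gives 2000 nM, the higher of the only two numbers so far. The next compound, compound 3 `Cc1ccc([C@H](C)NC(=O)Cn2nnc3ccccc3c2=O)cn1`, has the same atoms as compound 2, joined differently: 6-methylpyridin-3-yl stands in place of 5-methylpyridin-2-yl on a saturated chain carbon bound to an amide-type nitrogen and a saturated chain carbon. 6-methylpyridin-3-yl in place of 5-methylpyridin-2-yl on a saturated chain carbon bound to an amide-type nitrogen and a saturated chain carbon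

Going by the values given here, only one measured step bears on this change. It put 5-methylpyridin-2-yl in place of 4-bromophenyl at that same carbon and gave a 2.2-fold higher number from compound 1 to compound 2 (0.35 log units; beyond the scatter), a modest move. The new change is a different kind of swap, since one methylpyridine group replaces another with the same counts of atoms. Among the compounds with values here, no measured pair shows a swap of this kind, so the direction remains open and that modest step serves only as a rough guide to size. No step beyond the scatter is expected in this assay. The estimated step is a 1.3-fold higher number from compound 2 to compound 3 (0.10 log units; within the scatter). For compound 3 the expected value is 2500 nM, with an estimated range from 1000 nM to 6000 nM.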

Compound 3, solubility: 9800 nM
The estimate for compound 3 lay 3.9-fold (0.59 log units) below the measured number; the whole stated range lies below it.
By their numbers in this assay, from the lowest: compound 1; then compound 2; then compound 3.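

In this assay, the swap of 5-methylpyridin-2-yl for 6-methylpyridin-3-yl gives a 4.9-fold higher number from compound 2 to compound 3 (0.69 log units; beyond the scatter). The two groups have the same atoms and the same counts of heavy atoms and hydrogen-bond acceptors, so those counts alone do not set the number at this carbon, and how the atoms are joined matters as well. The step from 4-bromophenyl to 6-methylpyridin-3-yl, an 11-fold higher number from compound 1 to compound 3 (1.04 log units; beyond the scatter), is also much larger than the first step seen at this place, which shows that the choice of methylpyridine group decides how far a swap away from 4-bromophenyl carries, and nothing available here explains why the two methylpyridine groups differ.

The three compounds cannot show what the methyl contributes to this result, since no pyridin-3-yl group without it appears, nor whether an amine or a carboxylic acid in that group's place would keep the number as high. They also leave open whether the same rearrangement of atoms would give a step of similar size on a core other than the shared one.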